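The compounds below may be only part of what the source reports. "The series", "measured", "known", "first", "only" and "open" are said of these compounds alone.

Compound 1 `CC(C)c1cc(-n2nncc2-c2ccc(CN3CCN(c4ccccc4)CC3)cc2)c(O)cc1O` gives 520 nM
Compound 2 `CCNC(=O)c1nnn(-c2cc(C(C)C)c(O)cc2O)c1-c1ccc(CN2CCC[C@H](O)C2)cc1` gives 70 nM

In a functional assay on NCI-H460 cells (Homo sapiens) for inhibition, read by sulforhodamine B assay, with a stated time of 72 h (a lower number here means a stronger inhibitor, a higher number a weaker inhibitor), compound 2 holds the lower of the two numbers, and its gap to compound 1 lies beyond the usual scatter. Compound 3 `CCNC(=O)c1nnn(-c2cc(C(C)C)c(O)cc2O)c1-c1ccc(CN2CCNCC2)cc1` has not yet been measured. The change piperazin-1-yl in place of 3-hydroxypiperidin-1-yl on a saturated chain carbon bound to an aromatic carbon puts piperazin-1-yl in place of 3-hydroxypiperidin-1-yl on a saturated chain carbon bound to an aromatic carbon. For the measured compounds named here, no measured pair shows this swap alone, so in this assay no step beyond the scatter is expected, with only a slight lean towards weaker inhibition. The estimated step of a 1.4-fold higher number from compound 2 to compound 3 (0.15 log units; within the scatter) is expected to be small. Compound 3 is expected at 100 nM within a range of 35 nM to 300 nM in this estimate.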

Compound 3, half-maximal inhibitory concentration: 250 nM
The estimate for compound 3 lay 2.5-fold (0.40 log units) below the measured number, and the stated range covers the measured number.
By their numbers in this assay, from the lowest: compound 2; then compound 3; then compound 1.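

In this assay, piperazin-1-yl in place of 3-hydroxypiperidin-1-yl on a saturated chain carbon bound to an aromatic carbon gives a 3.6-fold higher number from compound 2 to compound 3 (0.55 log units; beyond the scatter) and so weakens inhibition by a modest step beyond the scatter. For the compounds shown here, this is the first direct comparison at this position, and it shows that the ring placed there affects the result. No measurement shown here explains the step. The pair leaves open whether the hydroxyl, the second ring nitrogen or the stereocentre matters most, and how a morpholine or an open-chain dimethylamino group would compare on the same carbon.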